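This account rests on a few compounds, and the source may have more. Where it says the series, first, only, none or still open, it means among the compounds named here.

In an ADME assay on MCF7 cells (Homo sapiens) for cytotoxicity, read by MTT assay, with a stated time of 72 h (a lower number here means a stronger inhibitor of growth, a higher number a weaker inhibitor of growth), compound 1, whose structure is `CCCCNC(=O)C1C(C(=O)O)[C@@H]2CC[C@H]1O2`, gives 10000 nM. It is level with its two measured companions. Compound 2, with the structure `O=C(O)C1C(C(=O)Nc2ccccc2)[C@H]2CC[C@@H]1O2`, gives 10000 nM in this assay, and compound 3, with the structure `Cn1ccc2cc(CNC(=O)C3C(C(=O)O)[C@@H]4CC[C@H]3O4)ccc21`, gives 10000 nM. Among the compounds with values here, the one step that can be read between them, no change at the digits printed from compound 1 to compound 2 (within the scatter), stays within the scatter, so swapping the group on the amide-type nitrogen left the read-out where it was.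

Compound 4 has the structure `O=C(O)CCCCCCCNC(=O)C1C(C(=O)O)[C@@H]2CC[C@H]1O2`. It differs from compound 1 by 3-carboxypropyl in place of hydrogen on a saturated chain carbon, four bonds along the chain from an amide-type nitrogen. The butyl chain of compound 1 is thus carried on and ends in a second acid group, while the shared core is untouched.

Within the data shown here, no measured step alters exactly this position, and the only measured step, the one from compound 1 to compound 2, shows that changing the group on the amide-type nitrogen made no difference beyond the scatter. With every measured compound sitting at the same value, there is no basis for expecting a shift in either direction, and the step of no change at the digits printed from compound 1 to compound 4 (within the scatter) is therefore expected to be flat. Compound 4 is accordingly estimated to give 10000 nM in this assay, within a range of 5000 nM to 20000 nM.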

Compound 4, concentration for 50% growth inhibition: 10000 nM
Compound 4: middle estimate and measured number agree at the digits printed; the range from low to high includes it.
By their numbers in this assay, from the lowest: compounds 1, 2, 3 and 4 (each within the scatter of the next).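

Within the data shown here, the step of no change at the digits printed from compound 1 to compound 4 (within the scatter) is the first look at the far end of the chain on the amide-type nitrogen. The earlier step replaced the whole butyl group with phenyl, whereas here the chain is kept and carried on by 3-carboxypropyl, so that it ends in a second carboxylic acid, and in this assay compound 4 gives 10000 nM, level with compound 1. This position therefore accepts a sizeable addition of 6 heavy atoms, including a new acid group, without any shift beyond the scatter, although nothing measured here offers an explanation for this result.

Because the added length and the added acid arrive together in compound 4, the compounds shown cannot separate what each does alone, and a plain longer chain with no acid at its end would be needed to tell them apart. Going by these compounds, an amine or a hydroxyl group at the end of the chain also lies outside these compounds, so it remains open whether any group at this position would move the number away from the value shared by all four.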